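Oral whole-animal inhibition: the step from compound 2 to compound 3

The source may report more compounds than this note shows. Statements on the series, on what has been measured and on what is new or still open speak of the compounds shown alone.

Two compounds of this series carry a number in a functional assay on the whole organism with Canis familiaris (Canis lupus familiaris) as the target, at a dose of 8 mg/kg by the oral route (on this read-out higher numbers stand for a stronger effect at the one dose given and lower numbers for a weaker effect), so far. Compound 1 `Cc1nc2cc(CCc3ccccc3)ccn2c1N` gives 0% in this assay. Compound 2 `Cc1nc2c(OCc3ccccc3)cccn2c1CN` gives 9% in this assay. Within the data shown here, compound 2 holds the higher of the two numbers, but its only neighbour, compound 1, lies within the scatter of it, so the two read-outs cannot be ordered and neither compound can be called the stronger.

Compound 3 `CCCNc1c(C)nc2c(OCc3ccccc3)cccn12` differs from compound 2 in a single place, (propylamino in place of aminomethyl on an aromatic carbon). Among the measured compounds shown here, no step between two measured compounds has been recorded, so there is nothing against which the size of this change can be gauged, and the two numbers in hand are both low. Compound 3 is expected to give 12% in this assay, with a range from 0% to 35%. That estimate means a step of a number 3 percentage points higher from compound 2 to compound 3 (within the scatter), expected to stay within the scatter rather than beyond it, with a small allowance for a modest rise that the present data can neither support nor rule out.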

Compound 3, a percentage reported as inhibition, in the whole organism at one dose (the size of the read-out at that dose, not a potency): 68%
Compound 3: middle estimate off by 56 percentage points, on the low side; the whole stated range lies below it.
By their numbers in this assay, from the lowest: compounds 1 and 2 (each within the scatter of the next); then compound 3.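

In this assay, among these compounds, the aromatic carbon next to the ring nitrogen and next to the ring atom that bears a methyl group proves sensitive to the group it carries: propylamino in place of aminomethyl gives a number 59 percentage points higher from compound 2 to compound 3 (beyond the scatter), the first step that can be read as a real change. Aminomethyl and propylamino match in their hydrogen-bond donor and acceptor counts and in carrying no net charge, and propylamino has more heavy atoms, all of the addition being carbon, so a large step here occurs without any change in those counts. Nothing at hand accounts for the size of this step.

A single step cannot separate the length of the propyl chain from the different attachment of the amine nitrogen in the two groups, and compounds with methylamino, butylamino or a simple propyl group at this carbon would be needed to pull the two apart. Going by these compounds, it also remains open whether the step holds when the benzyloxy group of compound 3 is replaced by another group, such as methoxy.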